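A few compounds are considered here, and "the series" means these few. Any claim that something is new, unique, unknown or untested is made for them only; others in the source may bear on it.

Series notes. In a functional assay on MCF7 cells (Homo sapiens) for antiproliferative activity, read by MTT assay, with a stated time of 48 h (a lower number here means a stronger inhibitor, a higher number a weaker inhibitor), compound 1 `N#CC1=C(N)Oc2c(c3nc4ccccc4nc3c3ccccc23)C12C(=O)N(Cc1cnnn1-c1ccc([N+](=O)[O-])cc1)c1ccccc12` returns only a limit, > 50000 nM. Compound 2 `Cc1cccc(-n2nncc2CN2C(=O)C3(C(C#N)=C(N)Oc4c(N)cc5nc6ccccc6nc5c43)c3ccccc32)c1` likewise returns only a limit in this assay, > 50000 nM. Both values sit at the limit of > 50000 nM in this assay, at which 2 of the 2 values shown sit, so compound 2 stands at the limit and no number separates it from compound 1. Compound 3 `N#CC1=C(N)Oc2c(N)cc3nc4ccccc4nc3c2C12C(=O)N(Cc1cnnn1-c1ccccc1Br)c1ccccc12` differs from compound 2 by 2-bromophenyl in place of 3-methylphenyl on an aromatic nitrogen. With both measured compounds at the limit, no step beyond the scatter is expected in this assay from this change. Compound 3 is estimated at 60000 nM, between 20000 nM and 200000 nM. The expected step is a step that the limit leaves unreadable from compound 2 to compound 3.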

Compound 3, half-maximal inhibitory concentration: 30700 nM
Estimate against measurement, compound 3: 2.0-fold (0.29 log units) above; measured number inside the range.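

Within the data shown here, compound 3 is the first compound here to give a number rather than a limit in this assay, so this position can carry a readable value. Replacing the 3-methylphenyl group with a 2-bromophenyl group gives an at least 1.6-fold lower number from compound 2 to compound 3 (0.21 log units; that floor lies within the scatter). That step has only a floor, and its size stays unknown: the limit of > 50000 nM in this assay, at which 2 of the 3 values shown sit.

From the compounds shown here alone, whether the bromine or the loss of the methyl group matters more remains open. Going by these compounds, how an unsubstituted phenyl, a benzyl group or an aminophenyl would read at this position also remains open.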